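Bromo to Fluoro: Expected Cytotoxicity of Compound 3

A few compounds are considered here, and "the series" means these few. Any claim that something is new, unique, unknown or untested is made for them only; others in the source may bear on it.

For the measured compounds named here, compound 2 `O=C(N/N=C/c1ccc(Br)cc1)c1cccnc1` holds the only actual number in an ADME assay on HEL cells (Homo sapiens) for cytotoxicity, read by microscopy; on this read-out higher numbers stand for lower toxicity in this test and lower numbers for higher toxicity in this test: in this assay compound 2 gives 48 ug/mL. Compound 1 `O=C(N/N=C/c1ccccc1)c1cccnc1` reports only a limit in this assay, and compound 1 gives > 100 ug/mL, which is a limit of the test rather than a number. Going by the values given here, the sole measured step, an at least 2.0-fold lower number from compound 1 to compound 2 (0.31 log units; beyond the scatter), is the only evidence that bears on the change ahead, and it rests on compound 1 sitting at the limit of > 100 ug/mL in this assay, at which 1 of the 2 values shown sits, so its true size is not known beyond that.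

Compound 3 `O=C(N/N=C/c1ccc(F)cc1)c1cccnc1` differs from compound 2 by fluoro in place of bromo on an aromatic carbon. Among the compounds with values here, the one measured step went toward higher toxicity when bromo entered, and the present change removes that bromo while another halogen takes its place. The account therefore expects the number to move back upward for compound 3, probably not all the way to the limit, with a fair chance that the assay again reports only a limit. The expected step is a 1.8-fold higher number from compound 2 to compound 3 (0.25 log units; within the scatter). Compound 3 is estimated at 85 ug/mL, with a range from 45 ug/mL to 160 ug/mL.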

Compound 3, half-maximal cytotoxic concentration: > 100 ug/mL
Compound 3 ended at the assay's limit (the forecaster's own chance of this, stated with the estimate: 40%); middle value at least 1.1-fold (0.07 log units) away from the limit.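

In this assay, fluoro in place of bromo on this aromatic carbon, para to a large group, gives an at least 2.0-fold higher number from compound 2 to compound 3 (0.31 log units; beyond the scatter), so the lower number seen with compound 2 does not carry over to every halogen placed here: among the two halogens shown, only bromo brings a number down, and fluoro does not bring it within the range of the test. Compound 3 gives > 100 ug/mL, which is a limit and not a number. The true size of the step from bromo to fluoro therefore remains unknown, and the read-out has little room to separate compounds at this end of the test: the limit of > 100 ug/mL in this assay, at which 2 of the 3 values shown sit.

Compound 1 and compound 3 both report limits, so the step between them cannot be read, and whether fluoro differs at all from hydrogen at this position stays unresolved. Also open, going by these compounds, is whether the lower number follows bromo alone or extends to other groups on this carbon, such as chloro, iodo, an amine or a carboxylic acid.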